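Bromo for cyano on the core aryl of the diisopropyl urea

The compounds below may be only part of what the source reports. "The series", "measured", "known", "first", "only" and "open" are said of these compounds alone.

Going by the values given here, compound 3 `CC(C)N(CCN(C(=O)Nc1ccc(F)c(F)c1)C1CC[C@]2(c3cccc(C#N)c3)CC2C1)C(C)C` gives the lowest number of the three measured members in a functional assay for antagonist activity at melanin-concentrating hormone receptor 1 (Homo sapiens) (on this read-out lower numbers stand for stronger inhibition and higher numbers for weaker inhibition), at 2.8 nM. Compound 1 `N#Cc1cccc([C@]23CCC(N(CCN4CC[C@@H](O)C4)C(=O)Nc4cccc(Br)c4)CC2C3)c1` gives 34 nM in this assay, and compound 2 `N#Cc1cccc(NC(=O)N(CCN2CC[C@@H](O)C2)C2CC[C@]3(c4cccc(C#N)c4)CC3C2)c1` gives 92 nM. The difference between the core of compound 2 and the core of compound 3 is not broken down here.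

Among the compounds with values here, the one measured step of the kind in question is bromo in place of cyano on an aromatic carbon, which gave a 2.7-fold lower number from compound 2 to compound 1 (0.43 log units; beyond the scatter). The same kind of change is now applied to compound 3 to give compound 4 `CC(C)N(CCN(C(=O)Nc1ccc(F)c(F)c1)C1CC[C@]2(c3cccc(Br)c3)CC2C1)C(C)C`, namely (bromo in place of cyano on an aromatic carbon). The place line reads the same in both cases, but the wider cut shows the two changes sit on different aryl rings: in the step from compound 2 to compound 1 the further cut also reads (3-cyanophenyl)amino to (3-bromophenyl)amino, whereas for compound 3 to compound 4 it reads only 3-cyanophenyl to 3-bromophenyl.

Within the data shown here, for compound 4 a step no larger than the earlier one is expected, a 1.1-fold lower number from compound 3 to compound 4 (0.05 log units; within the scatter), and quite possibly one within the scatter, because compound 3 already sits at 2.8 nM and the single precedent lies on the other aryl ring. The estimate for compound 4 in this assay is 2.5 nM, with a range from 0.8 nM to 8 nM.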

Compound 4, inhibition constant: 7.76 nM
For compound 4 the middle estimate is 3.1-fold (0.49 log units) below the measured one; the measured number falls inside the stated range.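

In this assay the change read as bromo in place of cyano on an aromatic carbon gives a 2.8-fold higher number from compound 3 to compound 4 (0.44 log units; beyond the scatter), so the lower number of the earlier step does not carry over and the direction reverses: the same change on two cores in this assay, a 2.7-fold lower number (0.43 log units; beyond the scatter) from compound 2 to compound 1 and a 2.8-fold higher number (0.44 log units; beyond the scatter) from compound 3 to compound 4, 7.5-fold (0.88 log units) apart, beyond the scatter of two such steps

Within these compounds, then, this change cannot be treated as a fixed increment that transfers from one core to another, in either size or direction. What the pair of steps does not show is which structural difference separates them: the earlier step reads (3-cyanophenyl)amino to (3-bromophenyl)amino and the new one reads 3-cyanophenyl to 3-bromophenyl, so they sit on different aryl rings, and compound 1 and compound 4 also differ in their side chains and in the rest of the urea, leaving the ring and the surrounding structure inseparable with one step each.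

The compounds shown leave open whether 3-cyanophenyl to 3-bromophenyl gives the same step when the diisopropylamino chain of compound 3 is replaced by the side chain of compound 1. Also open, from the compounds shown here alone, is how a chloro or a methoxy group would read in place of the cyano of compound 3.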